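Swapping dimethylamino for methyl on the shared core

The source may report more compounds than this note shows. Statements on the series, on what has been measured and on what is new or still open speak of the compounds shown alone.

- compound 1 `CNc1nc(-c2cc(OC)c(OC)c(OC)c2)c(-c2ccc3ccccc3c2)s1` gives 151 nM
- compound 2 `COc1cc(-c2nc(N(C)C)sc2-c2ccc3ccccc3c2)cc(OC)c1OC` gives 2900 nM
- compound 3 `COc1cc(-c2nc(N(C)C)sc2-c2ccc(C(F)(F)F)cc2)cc(OC)c1OC` gives > 10000 nM (a limit of the assay)

In a functional assay on A549 cells (Homo sapiens) for antiproliferative activity, read by MTT assay, with a stated time of 72 h (on this read-out lower numbers stand for stronger inhibition and higher numbers for weaker inhibition), compound 2 gives 2900 nM as the higher of the two exact numbers, with compound 1 nearest. Compound 3 is known only as a limit. Compound 4 `COc1cc(-c2nc(C)sc2-c2ccc3ccccc3c2)cc(OC)c1OC` differs from compound 2 by methyl in place of dimethylamino on an aromatic carbon and is otherwise the same. The step of a 19-fold higher number from compound 1 to compound 2 (1.28 log units; beyond the scatter) was large and concerns the group on this same carbon. The step of an at least 3.4-fold higher number from compound 2 to compound 3 (0.53 log units; beyond the scatter) concerns the naphthalen-2-yl group that compound 4 keeps, so it bears less on this change. A modest move toward a lower number is therefore expected, the estimate being a 1.9-fold lower number from compound 2 to compound 4 (0.29 log units; within the scatter) with wide uncertainty. Compound 4 is estimated at 1500 nM with an expected range from 300 nM to 8000 nM overall.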

Compound 4, half-maximal inhibitory concentration: 119 nM
For compound 4 the middle estimate is 13-fold (1.10 log units) above the measured one; measured number outside the range, below it.
By their numbers in this assay, from the lowest: compounds 4 and 1 (each within the scatter of the next); then compound 2. At a limit, above all of these: compound 3.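

In this assay methyl in place of dimethylamino gives a 24-fold lower number from compound 2 to compound 4 (1.39 log units; beyond the scatter) and so shows that this carbon does not reject every small group. Methyl in place of methylamino gives a 1.3-fold lower number from compound 1 to compound 4 (0.10 log units; within the scatter) and leaves those two values inseparable. Among the three groups shown here on the naphthalen-2-yl compounds, only dimethylamino stands apart, with the higher number.

On these data alone, whether a plain amine or an ethyl group on this carbon would behave like methyl remains open. Nothing measured here explains why dimethylamino stands apart.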